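Two Scaffolds, One Amine Swap, and an Expected Inhibition

This account rests on a few compounds, and the source may have more. Where it says the series, first, only, none or still open, it means among the compounds named here.

Compound 1, `CCN(CC)Cc1ccc(/C=C2\COc3cc(OC)c(OC)cc3C2=O)cc1O`: 9.5%
Compound 2, `COc1ccccc1CN(C)Cc1ccc(/C=C2\COc3cc(OC)c(OC)cc3C2=O)cc1O`: 12.3%
Compound 3, `CCN(CC)Cc1c(O)cccc1/C=C1\COc2cc(OC)c(OC)cc2C1=O`: 8.5%

These three compounds were tested in an assay on isolated protein for inhibition of Amine oxidase [flavin-containing] A (Homo sapiens), read by fluorescence, with a stated time of 30 min, tested at 20 uM; a lower number here means less inhibition, a higher number more inhibition at the concentration tested (going by the name of the read-out). Compound 1 and compound 2 share a core and differ by (2-methoxybenzyl)(methyl)amino in place of diethylamino on a saturated chain carbon bound to an aromatic carbon; the measured change was a number 2.8 percentage points higher from compound 1 to compound 2 (within the scatter), so both numbers sit close together. Compound 3 has the same atoms as compound 1 joined differently; the difference between the two cores is not broken down here. In this assay compound 3 gives a number within the scatter of compound 1 and of compound 2.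

Compound 4, `COc1ccccc1CN(C)Cc1c(O)cccc1/C=C1\COc2cc(OC)c(OC)cc2C1=O`, has not yet been measured. It differs from compound 3 by (2-methoxybenzyl)(methyl)amino in place of diethylamino on a saturated chain carbon bound to an aromatic carbon, the same change as between compound 1 and compound 2. The expected step is a number 2.8 percentage points higher from compound 3 to compound 4 (within the scatter), similar in size to the earlier step because a number 2.8 percentage points higher from compound 1 to compound 2 (within the scatter) was itself within the scatter. Compound 4 is therefore estimated at 11.3%, with a likely range from 3% to 20%.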

Compound 4, a percentage reported as inhibition, at one concentration (the size of the read-out at that concentration, not a potency): 9.8%
Compound 4: middle estimate off by 1.5 percentage points, on the high side; measured number inside the range.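

In this assay putting (2-methoxybenzyl)(methyl)amino in place of diethylamino gives a number 1.3 percentage points higher from compound 3 to compound 4 (within the scatter) on the second core. Set beside the earlier step, the change reads alike on both cores: the same change on two cores in this assay, a number 2.8 percentage points higher (within the scatter) from compound 1 to compound 2 and a number 1.3 percentage points higher (within the scatter) from compound 3 to compound 4, 1.5 percentage points apart, within the scatter of two such steps. This shows that the swap moves the number little on either core, but with both steps inside the scatter it does not show a real gain that carries from one core to the other, and two cores say nothing about any further core.

The compounds shown leave open what a different amine, such as morpholine or piperazine, would do on the saturated chain carbon bound to an aromatic carbon. They also leave open whether a carboxylic acid there would give a number clearly apart from these.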